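Ethylsulfanyl in Place of Methylsulfanyl on the Bromo Compound

This account rests on a few compounds, and the source may have more. Where it says the series, first, only, none or still open, it means among the compounds named here.

Measured so far in a functional assay on the whole organism (strain Sprague-Dawley) with Rattus norvegicus as the target, read by paw edema, with a stated time of 3 h, at a dose of 50 mg/kg by the oral route; on this read-out lower numbers stand for less inhibition and higher numbers for more inhibition at the one dose given (going by the name of the read-out):
compound 1, `CCSc1ncc(-c2ccc(S(C)(=O)=O)cc2)n1-c1ccc(F)cc1`, gives 65%;
compound 2, `CCSc1ncc(-c2ccc(S(C)(=O)=O)cc2)n1-c1ccc(Cl)cc1`, gives 53.8%;
compound 3, `CSc1ncc(-c2ccc(S(C)(=O)=O)cc2)n1-c1ccc(Br)cc1`, gives 90.7%.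

Compound 3 stands highest of the three, beyond the scatter above both others. Compound 4, `CCSc1ncc(-c2ccc(S(C)(=O)=O)cc2)n1-c1ccc(Br)cc1`, differs from it by methyl in place of hydrogen on a saturated chain carbon bound to a sulfur. Going by the values given here, the only measured step, a number 11.2 percentage points lower from compound 1 to compound 2 (beyond the scatter), concerns the halogen and not the chain on the sulfur, so it does not bear on this change. Among the compounds with values here, compounds 1 and 2 carry the ethylsulfanyl group and both sit lower than compound 3, but they also carry other halogens, so no measured step isolates the methyl-to-ethyl change. The expectation for compound 4 is therefore uncertain: a modest drop, a number 18.7 percentage points lower from compound 3 to compound 4 (beyond the scatter), is estimated, giving an expected 72% within the range 45% to 95%.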

Compound 4, a percentage reported as inhibition, in the whole organism at one dose (the size of the read-out at that dose, not a potency): 66%
Estimate against measurement, compound 4: 6 percentage points above, within the range that was stated.
By their numbers in this assay, from the lowest: compound 2; then compounds 1 and 4 (each within the scatter of the next); then compound 3.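

In this assay, methyl in place of hydrogen on the chain bound to the sulfur gives a number 24.7 percentage points lower from compound 3 to compound 4 (beyond the scatter), so with bromo held fixed, this position responds to the change from methylsulfanyl to ethylsulfanyl. With ethylsulfanyl held fixed, bromo in place of chloro gives a number 12.2 percentage points higher from compound 2 to compound 4 (beyond the scatter), while bromo in place of fluoro gives a number 1 percentage points higher from compound 1 to compound 4 (within the scatter), so the halogen also matters, though not for every swap. The bromo group alone therefore does not carry the high number of compound 3.

Still open, on these data alone, is whether a longer chain on the sulfur, such as propyl, would follow the same direction, and whether the fluoro and chloro compounds respond to methylsulfanyl as the bromo compound does. No measurement at hand accounts for these steps.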